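Sulfone for sulfide on two related cores

The compounds below may be only part of what the source reports. "The series", "measured", "known", "first", "only" and "open" are said of these compounds alone.

Compound 2 `CSc1cc(F)ccc1NCC1=NCCN1` carries a methylsulfanyl group on its aromatic ring, and in a functional assay for agonist activity at Alpha-1B adrenergic receptor (Homo sapiens) (on this read-out higher numbers stand for an effect only at larger amounts of compound and lower numbers for an effect already at smaller amounts), compound 2 gives 6.03 nM. Compound 1 `CS(=O)(=O)c1cc(F)ccc1NCC1=NCCN1` differs from it by the change (methylsulfonyl in place of methylsulfanyl on an aromatic carbon). For compound 1 the this assay reports only a limit, < 100000 nM. The step that the limit leaves unreadable from compound 2 to compound 1 therefore has no readable size, as the limit of < 100000 nM in this assay, at which 1 of the 3 values shown sits, shows; only its direction, toward an effect at larger amounts of compound, can be seen.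

Compound 3 `CSc1c(F)cccc1NCC1=NCCN1` is built from the same atoms as compound 2, joined differently; the difference between the two cores is not broken down here. In this assay compound 3 gives 85.1 nM.

Compound 4 `CS(=O)(=O)c1c(F)cccc1NCC1=NCCN1` has not yet been measured. It stands to compound 3 as compound 1 stands to compound 2, through the change (methylsulfonyl in place of methylsulfanyl on an aromatic carbon). The surroundings are not identical, though: in compound 4 the entering group sits ortho to a fluoro group, whereas in compound 1 it sits meta to a fluoro group, so this is the same kind of change rather than the same change.

Among the measured compounds shown here, only one earlier example exists, and it ends at a limit, so the expected step of a 350-fold higher number from compound 3 to compound 4 (2.55 log units; beyond the scatter) rests on the direction of a step that the limit leaves unreadable from compound 2 to compound 1 alone. For compound 4 the value expected in this assay is 30000 nM, within an estimated range from 3000 nM to 100000 nM.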

Compound 4, half-maximal effective concentration: < 100000 nM
Compound 4: only a limit was reported; the forecaster's own chance of this, stated with the estimate: 45%; the middle value does not contradict the limit.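

In this assay compound 4 is reported only as a limit, so the change from compound 3 to compound 4 has no readable size, only a direction toward an effect at larger amounts of compound: the limit of < 100000 nM in this assay, at which 2 of the 4 values shown sit.

The compounds shown leave open how large the change from methylsulfanyl to methylsulfonyl really is, and whether its size differs between the core of compound 2 and the core of compound 3.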